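This account rests on a few compounds, and the source may have more. Where it says the series, first, only, none or still open, it means among the compounds named here.

Compounds measured in an assay on isolated protein for inhibition of Myeloperoxidase (Homo sapiens), with a stated time of 10 min; a lower number here means a stronger inhibitor, a higher number a weaker inhibitor:
Compound 1, `Nc1cc(Cc2ccn(Cc3cccc(Oc4ccccc4)c3)n2)c2nn[nH]c2n1`: 44 nM
Compound 2, `Nc1cc(C2CCNCCc3cccc(c3)OCc3cccc(c3)Cn3cc2cn3)c2nn[nH]c2n1`: 17 nM
Compound 3, `Nc1cc(Cc2ccn(Cc3cccc(-c4ccccc4)c3)n2)c2nn[nH]c2n1`: 55 nM

Compound 3 gives the highest of the three numbers. Among the measured compounds shown here, compound 1 stands nearest to it, and the difference between the two stays within the usual scatter, as the single measured step shows: a 1.3-fold higher number from compound 1 to compound 3 (0.10 log units; within the scatter). For the measured compounds named here, compound 2 lies furthest away, with a lower number that is beyond the scatter; the two structures differ in more than one place, so no single step links them.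

Compound 4, `Nc1cc(Cc2ccn(Cc3cccc(Cc4ccccc4)c3)n2)c2nn[nH]c2n1`, has not yet been measured. It differs from compound 3 in one place: benzyl in place of phenyl on an aromatic carbon. Going by the values given here, only one measured step touches this position, namely a 1.3-fold higher number from compound 1 to compound 3 (0.10 log units; within the scatter), in which the group at the same place was exchanged and the number hardly moved. Because a 1.3-fold higher number from compound 1 to compound 3 (0.10 log units; within the scatter) stayed within the scatter, a further exchange at this place is expected to give no step beyond the scatter either, in no clear direction. The expected step is therefore a 1.1-fold lower number from compound 3 to compound 4 (0.04 log units; within the scatter). Compound 4 is estimated to give 50 nM in this assay, with a range from 20 nM to 130 nM.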

Compound 4, half-maximal inhibitory concentration: 39 nM
For compound 4 the middle estimate is 1.3-fold (0.11 log units) above the measured one, and the stated range covers the measured number.
By their numbers in this assay, from the lowest: compound 2; then compounds 4, 1 and 3 (each within the scatter of the next).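

In this assay the step of a 1.4-fold lower number from compound 3 to compound 4 (0.15 log units; within the scatter) and the step of a 1.1-fold lower number from compound 1 to compound 4 (0.05 log units; within the scatter) both stay small, so benzyl cannot be told apart from either phenyl or phenoxy on this aromatic carbon, meta to a large group. Among the compounds shown here, the earlier compounds offered only one exchange at this place, and compound 4 turns it into a set of three: the outer aromatic ring can sit directly on the aromatic carbon or be joined through an oxygen or a carbon, and in these three compounds the number stays within the scatter each time. No measurement is available that bears on why these three groups give such similar numbers.

As far as these compounds go, all three groups carry one six-membered aromatic ring of carbon only, so it remains open whether an amine, a carboxylic acid or a longer chain leading to the outer ring would also leave the number within the scatter. Compound 2 differs from compounds 1, 3 and 4 in more than one place, so its lower number says nothing about this exchange.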